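A few compounds are considered here, and "the series" means these few. Any claim that something is new, unique, unknown or untested is made for them only; others in the source may bear on it.

Working notes on the series. Compound 3 `COc1cc2nc(N3CCN(C(=O)OCc4ccccc4)[C@@H]4CCCC[C@@H]43)nc(N)c2cc1OC` gives the lowest number of the three measured in an assay on CHO cells for displacement of a labelled ligand from Alpha-1D adrenergic receptor (Homo sapiens), with a stated time of 30 min (on this read-out higher numbers stand for weaker inhibition and lower numbers for stronger inhibition), at 0.0398 nM; compound 1 `CCCCCC(=O)N1CCN(c2nc(N)c3cc(OC)c(OC)cc3n2)[C@@H]2CCCC[C@@H]21` gives 3.72 nM and compound 2 `COc1cc2nc(N3CCN(C(=O)C(C)(C)C)[C@H]4CCCC[C@H]43)nc(N)c2cc1OC` gives 6.17 nM, both well beyond the scatter from compound 3. Compound 4 `COc1cc2nc(N3CCN(C(=O)OCc4ccccc4)[C@H]4CCCC[C@H]43)nc(N)c2cc1OC` differs from compound 3 only in configuration: the two compounds have the same atoms and bonds and differ only in configuration as drawn: 2 of 2 stereo elements differ (all stereocentres are inverted: mirror images); a stereocentre at a saturated ring carbon is drawn R in compound 3 and S in compound 4; a stereocentre at a saturated ring carbon is drawn S in compound 3 and R in compound 4. Going by the values given here, no measured step isolates this change; the one step recorded, a 1.7-fold higher number from compound 1 to compound 2 (0.22 log units; within the scatter), swaps the acyl group, and compounds 1 and 2 differ in ring configuration as well as acyl group, so their values show only that both sit close together. Inversion of both centres may weaken binding, but the evidence is thin. Compound 4 is therefore expected to move by a 7.5-fold higher number from compound 3 to compound 4 (0.88 log units; beyond the scatter), to an estimated 0.3 nM (range 0.04 nM to 3 nM).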

Compound 4, inhibition constant: 3.98 nM
Beside the measured number, compound 4's estimate is 13-fold (1.12 log units) below it, outside the stated range (above it).
By their numbers in this assay, from the lowest: compound 3; then compounds 1, 4 and 2 (each within the scatter of the next).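

In this assay there is a 100-fold higher number from compound 3 to compound 4 (2.00 log units; beyond the scatter), a large move that can be placed on the two ring stereocentres alone because of one fact: the fact that compounds 3 and 4 differ only in the configuration as drawn. The low number of compound 3 therefore depends on configuration as well as on benzyloxy. Compound 4 does not separate from the other two, with a 1.6-fold lower number from compound 2 to compound 4 (0.19 log units; within the scatter) and a 1.1-fold higher number from compound 1 to compound 4 (0.03 log units; within the scatter).

Open, as far as these compounds go, is whether the same inversion moves the number as far with pentyl or tert-butyl on the carbonyl carbon. Also open, from the compounds shown here alone, is how a longer chain or a carboxylic acid in place of benzyloxy would read in either configuration.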